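Swapping an Ester for a Benzyl Ether on the Shared Core

A few compounds are considered here, and "the series" means these few. Any claim that something is new, unique, unknown or untested is made for them only; others in the source may bear on it.

Compound 2 `COc1cccc(C(=O)Oc2ccc3c(=O)c(-c4cc(OC)c(OC)cc4OC)coc3c2)c1` carries a (3-methoxyphenyl)carbonyl on an oxygen on an aromatic ring of the shared core. In a functional assay on A-375 cells (Homo sapiens) for antiproliferative activity, read by MTT assay, with a stated time of 24 h (on this read-out higher numbers stand for weaker inhibition and lower numbers for stronger inhibition), compound 2 gives only a limit, > 10000 nM; its place among the three measured compounds is the limit of > 10000 nM in this assay, at which 1 of the 3 values shown sits. Two measured compounds differ from it in one place. Compound 1 `C=CCOc1ccc2c(=O)c(-c3cc(OC)c(OC)cc3OC)coc2c1`, with an allyl on that oxygen, gives 4750 nM in this assay, and the change to the ester brought an at least 2.1-fold higher number from compound 1 to compound 2 (0.32 log units; beyond the scatter). Compound 3 `COc1cc(OC)c(-c2coc3cc(OCc4ccccc4C#N)ccc3c2=O)cc1OC`, with a 2-cyanobenzyl on the same oxygen, gives 990 nM in this assay; the step of an at least 10-fold lower number from compound 2 to compound 3 (1.00 log units; beyond the scatter) is the largest seen here, while a 4.8-fold lower number from compound 1 to compound 3 (0.68 log units; beyond the scatter) also favours the benzyl ether.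

Compound 4 `COc1cc(OC)c(-c2coc3cc(OCc4ccc(C(F)(F)F)cc4)ccc3c2=O)cc1OC` is not yet measured. It differs from compound 2 as 4-(trifluoromethyl)benzyl in place of (3-methoxyphenyl)carbonyl on an oxygen on an aromatic ring. Within the data shown here, this step, like the one to compound 3, trades the ester for a benzyl ether bearing a single substituent, so the guide is the step to compound 3, though the substituent and its position on the benzyl ring differ, which widens the uncertainty. In this assay compound 4 is therefore expected to show a step of about an at least 6.6-fold lower number from compound 2 to compound 4 (0.82 log units; beyond the scatter). Compound 4 is estimated at 1500 nM, with a range from 500 nM to 5000 nM.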

Compound 4, half-maximal inhibitory concentration: 2280 nM
Compound 4: middle estimate off by 1.5-fold (0.18 log units), on the low side, and the stated range covers the measured number.
By their numbers in this assay, from the lowest: compound 3; then compound 4; then compound 1. At a limit, above all of these: compound 2.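

Compound 4 shows that the gain over the ester does not belong to the 2-cyanobenzyl of compound 3 alone: with 4-(trifluoromethyl)benzyl on the same oxygen, this assay again gives a clearly lower number (an at least 4.3-fold lower number from compound 2 to compound 4 (0.64 log units; beyond the scatter)). The substituent on the benzyl ring also matters, as the two benzyl ethers are separated beyond the scatter (a 2.3-fold higher number from compound 3 to compound 4 (0.36 log units; beyond the scatter)), yet compound 4 still reads lower than the allyl ether (a 2.1-fold lower number from compound 1 to compound 4 (0.32 log units; beyond the scatter)), so both benzyl ethers shown improve on the allyl. The step from the ester rests on a limit for compound 2, not on a number: (the limit of > 10000 nM in this assay, at which 1 of the 4 values shown sits)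

The compounds shown leave open whether the change of group or its place on the ring accounts for the gap between compound 3 and compound 4, as the two change together. As far as these compounds go, how a benzyl carrying an amine or a carboxylic acid, or a longer chain in place of the benzyl, would read on this oxygen also stays open.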